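Phenyl for thiophen-2-yl on a sulfur

The source may hold more compounds than are shown below. What is called first, only, known or untested is meant among the compounds shown, and "the series" means these compounds.

Values in an ADME assay on MDCK cells (Canis lupus familiaris) for cytotoxicity, read by MTT assay, with a stated time of 48 h (a lower number here means that less compound is tolerated, a higher number that more compound is tolerated), are all limits
- Compound 1 `CCC(CC)O[C@@H]1C=C(C(=O)O)C[C@H](NCc2ccc(OC)cc2)[C@H]1NC(C)=O` gives > 250000 nM
- Compound 2 `CCC(CC)O[C@@H]1C=C(C(=O)O)C[C@H](NCc2ccc(SC3CCCCC3)cc2)[C@H]1NC(C)=O` gives > 250000 nM
- Compound 3 `CCC(CC)O[C@@H]1C=C(C(=O)O)C[C@H](NCc2ccc(Sc3cccs3)cc2)[C@H]1NC(C)=O` gives > 250000 nM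

Compound 3 stands at a limit (> 250000 nM) and not at a number. The whole series offers only the limit of > 250000 nM in this assay, at which 3 of the 3 values shown sit, and so gives no ranking.

Compound 4 `CCC(CC)O[C@@H]1C=C(C(=O)O)C[C@H](NCc2ccc(Sc3ccccc3)cc2)[C@H]1NC(C)=O` carries phenyl in place of thiophen-2-yl on a sulfur.

Going by the values given here, two measured steps bear on this change, a step that the two limits leave unreadable from compound 2 to compound 3 on the same sulfur and a step that the two limits leave unreadable from compound 1 to compound 3 with the whole group on the aromatic carbon replaced. Neither offers a size, so no step beyond the usual scatter is expected in this assay and no direction can be expected either. The estimated change is a number no higher from compound 3 to compound 4 (the limit leaves the size open) and no more than that.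

For compound 4 the expected value is 250000 nM (estimated range 120000 nM to 500000 nM).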

Compound 4, half-maximal cytotoxic concentration: > 250000 nM
Compound 4 gave a limit, no number; the forecaster's own chance of this, stated with the estimate: 85%; the middle value lies on the limit itself.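

Compound 4 gives > 250000 nM, which is a limit and not a number, so its steps from compound 1, compound 2 and compound 3 cannot be read. Whether these four compounds differ at all in this assay stays open: the limit of > 250000 nM in this assay, at which 4 of the 4 values shown sit.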